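From (diethylamino)methyl to amino on compound 2

The compounds below may be only part of what the source reports. "The series", "measured", "known", "first", "only" and "open" are said of these compounds alone.

For the measured compounds named here, in a functional assay on HepG2 cells (Homo sapiens), read by MTT assay, with a stated time of 48 h (on this read-out lower numbers stand for stronger inhibition and higher numbers for weaker inhibition), compound 2 `CCN(CC)CCCNC(=O)c1ccc(C(CC)(CC)c2ccc(OCC(=O)C(C)(C)C)c(C)c2)n1CC` gives 180 nM, the lower of the two numbers measured so far, while compound 1 `CCn1c(C(=O)NCCN(C)C)ccc1C(CC)(CC)c1ccc(OCC(=O)C(C)(C)C)c(C)c1` gives 2300 nM. Compound 3 `CCn1c(C(=O)NCCN)ccc1C(CC)(CC)c1ccc(OCC(=O)C(C)(C)C)c(C)c1` has not yet been measured. It departs from compound 2 by amino in place of (diethylamino)methyl on a saturated chain carbon, two bonds along the chain from an amide-type nitrogen, with amino in place of (diethylamino)methyl on a saturated chain carbon, two bonds along the chain from an amide-type nitrogen. Going by the values given here, only one measured step bears on this change: a 13-fold lower number from compound 1 to compound 2 (1.11 log units; beyond the scatter), where (diethylamino)methyl replaced dimethylamino at that same place. Among the compounds with values here, removing (diethylamino)methyl from compound 2 is therefore expected to run the other way, as a large step toward a higher number, although no amino compound has been measured. The expected step is an 11-fold higher number from compound 2 to compound 3 (1.05 log units; beyond the scatter). For compound 3 the estimated value is 2000 nM, with a range of 600 nM to 8000 nM.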

Compound 3, half-maximal inhibitory concentration: 180 nM
Beside the measured number, compound 3's estimate is 11-fold (1.05 log units) above it; the measured number lies below the stated range.
By their numbers in this assay, from the lowest: compounds 2 and 3 (each within the scatter of the next); then compound 1.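

In this assay, amino in place of (diethylamino)methyl on a saturated chain carbon, two bonds along the chain from an amide-type nitrogen, gives no change at the digits printed from compound 2 to compound 3 (within the scatter) so this place tolerates the loss of that whole group. Amino in place of dimethylamino at the same place gives a 13-fold lower number from compound 1 to compound 3 (1.11 log units; beyond the scatter) and so compound 1 alone stands apart: among these compounds the number does not follow group size, since the largest and smallest groups give the low number and dimethylamino, of intermediate size, the high one. Nothing measured here explains this.

From the compounds shown here alone, whether a methylamino group or a hydroxyl group at this place would keep the low number of compound 3 stays open. So does what a 3-aminopropyl chain would give in place of 2-aminoethyl.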